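The compounds below may be only part of what the source reports. "The series", "measured", "known", "first", "only" and "open" are said of these compounds alone.

Measured so far in an assay on HEK293 cells for inhibition of Voltage-dependent L-type calcium channel subunit alpha-1C (Homo sapiens), read by FLIPR and calcium flux, with a stated time of 3 min; a higher number here means a weaker inhibitor, a lower number a stronger inhibitor:
- compound 1 `O=C(NC1CCCCC1)N1N=C(c2ccc(Br)cc2)CC1c1ccc(F)cc1`: 1340 nM
- compound 2 `CC(C)NC(=O)N1N=C(c2ccc(Br)cc2)CC1c1ccc(F)cc1`: 2360 nM

Compound 2 stands at the higher of the two numbers, with compound 1 nearest; the step of a 1.8-fold higher number from compound 1 to compound 2 (0.25 log units; within the scatter) lies within the scatter, so the two compounds cannot be ordered on these data. The next compound, compound 3 `O=C(Nc1ccccn1)N1N=C(c2ccc(Br)cc2)CC1c1ccc(F)cc1`, is still to be measured in this assay. It differs from compound 2 in one place: pyridin-2-yl in place of isopropyl on an amide-type nitrogen. Among the measured compounds shown here, the only measured step at this nitrogen is a 1.8-fold higher number from compound 1 to compound 2 (0.25 log units; within the scatter), an exchange of one saturated group for another, and so far a change of group there has produced no shift beyond the scatter. For the measured compounds named here, no measured step covers an aromatic ring or a hydrogen-bond acceptor at this place, so the basis is thin. For compound 3 the step of a 1.5-fold lower number from compound 2 to compound 3 (0.17 log units; within the scatter) is expected to stay within the scatter, with a wide range to reflect the lack of a comparable step. The estimate for compound 3 is 1600 nM, with a range from 500 nM to 5000 nM.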

Compound 3, half-maximal inhibitory concentration: 2180 nM
For compound 3 the middle estimate is 1.4-fold (0.13 log units) below the measured one; the measured number falls inside the stated range.
By their numbers in this assay, from the lowest: compounds 1, 3 and 2 (each within the scatter of the next).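

At the amide-type nitrogen, pyridin-2-yl brings the only aromatic ring and hydrogen-bond acceptor among these groups, yet in this assay the change gives a 1.1-fold lower number from compound 2 to compound 3 (0.03 log units; within the scatter) and against the larger saturated group gives a 1.6-fold higher number from compound 1 to compound 3 (0.21 log units; within the scatter) with neither step leaving the scatter. Isopropyl, cyclohexyl and pyridin-2-yl are therefore not told apart at this place, so the aromatic ring with its acceptor adds no measurable shift in this small set. No measured evidence bears on this result.

Going by these compounds, whether an unsubstituted phenyl, a carboxylic acid or a longer chain ending in an amine at this nitrogen would move the number beyond the scatter stays open. On these data alone, the rest of the shared core is constant across compound 1, compound 2 and compound 3, so the effect of changes elsewhere also stays open.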